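This account rests on a few compounds, and the source may have more. Where it says the series, first, only, none or still open, it means among the compounds named here.

Compound 1 `CC(C)C(c1ccc(Cl)cc1)S(=O)(=O)Nc1nccs1` gives in a functional assay on CHO cells for agonist activity at Free fatty acid receptor 2 (Homo sapiens), read by cAMP accumulation (a higher number here means a weaker inhibitor, a lower number a stronger inhibitor), a value of > 100000 nM, which is a limit of the assay.
Compound 2 `CC(C)[C@H](C(=O)NCc1ccccc1)c1ccc(Cl)cc1` gives in this assay > 100000 nM, again a limit.
Compound 3 `CC(C)C(C(=O)Nc1ncccn1)c1ccc(Cl)cc1` gives in this assay 53000 nM.

Compound 2 thus stands at the limit of > 100000 nM in this assay, at which 2 of the 3 values shown sit, so no number is known for it, only that it lies beyond the measurable range. Compound 4 `CC(C)[C@H](C(=O)Nc1nncs1)c1ccc(Cl)cc1` differs from compound 2 by 1,3,4-thiadiazol-2-yl in place of benzyl on an amide-type nitrogen. Going by the values given here, no measured pair shows this change, so its effect can only be estimated. Compound 3, with an amide to a six-membered aromatic ring with two nitrogens, gives 53000 nM, which suggests that an amide to a heteroaryl ring can reach a measurable value. Compound 4 is therefore expected to show a step of an at least 2.5-fold lower number from compound 2 to compound 4 (0.39 log units; beyond the scatter) toward stronger activity, though a limit remains possible. Compound 4 is estimated at 40000 nM, between 8000 nM and 100000 nM.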

Compound 4, half-maximal inhibitory concentration: 12000 nM
For compound 4 the middle estimate is 3.3-fold (0.52 log units) above the measured one, and the stated range covers the measured number.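

With 1,3,4-thiadiazol-2-yl in place of benzyl on the amide-type nitrogen, this assay shows an at least 8.3-fold lower number from compound 2 to compound 4 (0.92 log units; beyond the scatter). Going by these compounds alone, this is the first step in which a single change at this position moves a compound from a limit of the assay to a measured number. The true size of the step stays unknown because compound 2 has only a limit: the limit of > 100000 nM in this assay, at which 2 of the 4 values shown sit.

The compounds shown leave open whether the step follows from the nitrogen atoms or the sulfur atom of the new ring. A phenyl or a pyridin-2-yl on the same amide-type nitrogen would help to separate these.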